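Nucleoside series: cytotoxicity and a ring-for-chain swap

The source may report more compounds than this note shows. Statements on the series, on what has been measured and on what is new or still open speak of the compounds shown alone.

Working notes on three measured compounds and one awaiting measurement in an ADME assay on L1210/0 cells (Mus musculus) for cytotoxicity, with a stated time of 48 h; a lower number here means a stronger inhibitor, a higher number a weaker inhibitor.

Among the measured compounds shown here, compound 1 `O=C(CI)NCc1cn([C@H]2C[C@H](O)[C@@H](CO)O2)c(=O)[nH]c1=O` gives 107000 nM in this assay, the only finished number in the set. Compound 2 `C[C@H](O)C1CC(Cn2cnc3c(N)ncnc32)C1(C)C` reaches only the limit of this assay, > 200000 nM. Compound 3 `Nc1ccn(COCCO)c(=O)n1` likewise returns only the limit, > 200000 nM. Where compound 1 stands is therefore defined by a single number against (the limit of > 200000 nM in this assay, at which 2 of the 3 values shown sit). For the measured compounds named here, no pair of measured compounds differs in one place, so no measured step is available to anchor a change.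

Compound 4 `O=c1[nH]c(=O)n([C@H]2C[C@H](O)[C@@H](CO)O2)cc1C1SCCS1` is the next compound for this assay. It differs from compound 1 by a group of 5 heavy atoms (3 carbon, 2 sulfur; one five-membered non-aromatic ring with 2 hetero atoms) in place of a group of 6 heavy atoms (3 carbon, 1 nitrogen, 1 oxygen, 1 iodine; no ring), on an aromatic carbon. The group that leaves carries the (iodomethyl)carbonyl; the group that enters is a five-membered non-aromatic ring with two sulfur atoms and no hydrogen-bond donor.

Going by the values given here, with no measured step to lean on, the expectation for compound 4 rests on the position of compound 1 and on the two compounds sitting at the limit. The step is expected to be small and toward weaker inhibition, a 1.9-fold higher number from compound 1 to compound 4 (0.27 log units; within the scatter), with a real chance that compound 4 reports only a limit. Compound 4 is estimated at 200000 nM, between 60000 nM and 600000 nM.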

Compound 4, half-maximal inhibitory concentration: > 200000 nM
Compound 4 gave a limit, no number; the forecaster's own chance of this, stated with the estimate: 55%; the middle value sits exactly at the limit.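

Placing the five-membered ring with two sulfur atoms on this aromatic carbon, where compound 1 carries the (((iodomethyl)carbonyl)amino)methyl group, gives an at least 1.8-fold higher number from compound 1 to compound 4 (0.27 log units; that floor lies within the scatter) in this assay. Compound 4 returns > 200000 nM, which is a limit and not a number, so the step is only a floor and does not by itself separate compound 4 from compound 1. Within the compounds shown, the only finished number at this position therefore still belongs to the (((iodomethyl)carbonyl)amino)methyl group of compound 1, and the limit is now the commonest reading in the set: the limit of > 200000 nM in this assay, at which 3 of the 4 values shown sit.

The compounds shown leave open whether the finished number of compound 1 depends on the iodine or on the amide chain as a whole. An acetamidomethyl group, with a methyl in place of the iodomethyl, or a chloroacetamidomethyl group on the same aromatic carbon of the shared core would bear on that question, and a measured number for either would give the series a step that can be read in full.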